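One Added Methoxy on the Core of Compound 1

The source may report more compounds than this note shows. Statements on the series, on what has been measured and on what is new or still open speak of the compounds shown alone.

- compound 1 `COc1cc(OC)c2sc(-c3ccc(N/C=C\C(=O)c4cc(OC)c(OC)c(OC)c4)cc3)nc2c1`: 26800 nM
- compound 2 `COc1cc(OC)c2sc(-c3ccc(N/C=C\C(=O)c4cc(OC)c(OC)c([N+](=O)[O-])c4)cc3)nc2c1`: 12700 nM
- compound 3 `COc1cc(OC)c2sc(-c3ccc(N/C=C\C(=O)c4cc(OC)c(OC)c(OC)c4Br)cc3)nc2c1`: 19000 nM

In a functional assay on MIA PaCa-2 cells (Homo sapiens) for antiproliferative activity, read by sulforhodamine B assay, with a stated time of 48 h (on this read-out higher numbers stand for weaker inhibition and lower numbers for stronger inhibition), the nearest measured neighbour of compound 1 is reached by a 1.4-fold lower number from compound 1 to compound 3 (0.15 log units; within the scatter), and the furthest by a 2.1-fold lower number from compound 1 to compound 2 (0.32 log units; beyond the scatter). Compound 4 `COc1cc(C(=O)/C=C\Nc2ccc(-c3nc4cc(OC)c(OC)c(OC)c4s3)cc2)cc(OC)c1OC` differs from compound 1 in the shared core: methoxy in place of hydrogen on an aromatic carbon. The new methoxy stands ortho to two methoxy groups. Neither measured step touches the core, so both are only loose guides. The larger, a 2.1-fold lower number from compound 1 to compound 2 (0.32 log units; beyond the scatter), is modest, so no step beyond the scatter is expected in this assay, in either direction. The expected change is a 1.2-fold lower number from compound 1 to compound 4 (0.09 log units; within the scatter). For compound 4 the estimated value is 22000 nM, with an expected range of 9000 nM to 50000 nM.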

Compound 4, half-maximal inhibitory concentration: 29100 nM
The estimate for compound 4 lay 1.3-fold (0.12 log units) below the measured number; low and high end bracket the measured number.
By their numbers in this assay, from the lowest: compounds 2, 3, 1 and 4 (each within the scatter of the next, the first and the last beyond it).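

In this assay, methoxy in place of hydrogen on the shared core, ortho to two methoxy groups, gives a 1.1-fold higher number from compound 1 to compound 4 (0.04 log units; within the scatter). Within the data shown here, this is the first step here that touches the core, and at this carbon the methoxy leaves compound 1 and compound 4 indistinguishable within the scatter. No measurement shown bears on this result. On these data alone, whether an amine, a carboxylic acid or a longer chain at this carbon would also stay within the scatter remains open. So does the effect of this methoxy alongside the nitro or the bromo.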